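Three Related Compounds in a Liver-Cell Toxicity Assay

The compounds below may be only part of what the source reports. "The series", "measured", "known", "first", "only" and "open" are said of these compounds alone.

In an ADME assay on HepG2 cells (Homo sapiens) for cytotoxicity, read by CellTiter-Glo and resazurin assay, with a stated time of 72 h (on this read-out lower numbers stand for an effect already at smaller amounts and higher numbers for an effect only at larger amounts of compound), compound 1 `CC(C)N(Cc1cccc(OCCCCCC(=O)O)c1)C(=O)c1ccc(-c2cccc3ccccc23)cc1` gives > 26000 nM, a limit of the assay and not a number. Compound 2 `CC(C)N(Cc1cccc(OCCCCCC(=O)O)c1)C(=O)c1ccc(-c2ccc3c(c2)OCCO3)cc1` gives > 21900 nM in this assay, again a limit. Because both sit at limits, a step that the two limits leave unreadable from compound 1 to compound 2 cannot be read. Compound 2 stands at the limit of > 21900 nM in this assay, at which 1 of the 2 values shown sits. The other value shown is the limit of > 26000 nM in this assay, at which 1 of the 2 values shown sits. Compound 3 `CC(C)N(Cc1cccc(OCCCCCC(=O)O)c1)C(=O)c1ccc(-c2ccc3cc[nH]c3c2)cc1` differs from compound 2 by 1H-indol-6-yl in place of 2,3-dihydro-1,4-benzodioxin-6-yl on an aromatic carbon. No readable step bears on this change, so no shift beyond the scatter is expected in this assay. Compound 3 is therefore estimated at 30000 nM (range 10000 nM to 100000 nM), an expected step that the limit leaves unreadable from compound 2 to compound 3.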

Compound 3, half-maximal effective concentration: > 26000 nM
Compound 3: only a limit was reported (the forecaster's own chance of this, stated with the estimate: 80%); the middle value is on the limit's open side.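

Going by these compounds alone, compound 1, compound 2 and compound 3 all give limits in this assay, and no step among them can be read. Left open is the concentration at which each compound would show an effect, and whether exchanging the group changes it.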